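A Second Phenyl Ring on the Shared Core

The source may report more compounds than this note shows. Statements on the series, on what has been measured and on what is new or still open speak of the compounds shown alone.

Compound 1 `Cc1c(-c2ccccc2)sc(N)c1C(=O)c1ccc(Cl)cc1` and compound 2 `Cc1sc(N)c(C(=O)c2ccc(Cl)cc2)c1-c1ccccc1` share one core and differ only in where the methyl and phenyl groups sit on it. In an assay on CHO cells for displacement of a labelled ligand from adenosine receptor A3 (Homo sapiens), read by scintillation counting, tested at 10 uM (on this read-out lower numbers stand for less inhibition and higher numbers for more inhibition at the one concentration tested (going by the name of the read-out)), compound 1 gives 1%. Compound 2 stands level with it: in this assay compound 2 gives 1%, no change at the digits shown and well within the usual scatter. Both values lie at the very bottom of the scale. Compound 3 `Nc1sc(-c2ccccc2)c(-c2ccccc2)c1C(=O)c1ccc(Cl)cc1` arises from compound 2 by the change (phenyl in place of methyl on an aromatic carbon). Among the compounds with values here, no step between measured compounds is available to gauge a change of this kind, and the two measured compounds show that either arrangement of methyl and phenyl leaves the read-out near zero. The step of a number 4 percentage points higher from compound 2 to compound 3 (within the scatter) is therefore expected to be small, in either direction and likely within the scatter. Compound 3 is estimated to give 5%, with a range from 0% to 20%.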

Compound 3, a percentage reported as inhibition, at one concentration (the size of the read-out at that concentration, not a potency): 1%
The estimate for compound 3 lay 4 percentage points above the measured number; low and high end bracket the measured number.
By their numbers in this assay, from the lowest: compounds 1, 2 and 3 (each within the scatter of the next).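

In this assay, the step of no change at the digits printed from compound 2 to compound 3 (within the scatter) shows that phenyl in place of methyl on the aromatic carbon next to the ring sulfur does not lift the read-out from the bottom of the scale. The step of no change at the digits printed from compound 1 to compound 3 (within the scatter) is the same exchange made at the methyl of compound 1, and it too leaves the number at the bottom of the scale, so the shared core with two phenyl groups reads the same as with one phenyl and one methyl. Nothing available explains this flat result.

On these data alone, with all three compounds at the bottom of the scale, it remains open whether this position responds to any group at all. An amine, a carboxylic acid or a longer chain such as butyl on this carbon could still give a different reading.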